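A few compounds are considered here, and "the series" means these few. Any claim that something is new, unique, unknown or untested is made for them only; others in the source may bear on it.

Compound 2 `COc1cc(-c2cc(/C=C/C(=O)c3ccc(Cl)c(Cl)c3)[nH]n2)cc(OC)c1OC` and compound 1 `COc1cc(-c2cc(/C=C/C(=O)c3ccc(N)cc3)[nH]n2)cc(OC)c1OC` share one core and differ only in the aryl group on the carbonyl carbon. In a functional assay on SF-539 cells (Homo sapiens) for inhibition, read by sulforhodamine B assay, with a stated time of 48 h (a lower number here means a stronger inhibitor of growth, a higher number a weaker inhibitor of growth), compound 1 gives 1300 nM and compound 2 gives 4310 nM; compound 2 thus stands highest of the two numbers, the step of a 3.3-fold higher number from compound 1 to compound 2 (0.52 log units; beyond the scatter) being beyond the scatter. Compound 3 `COc1ccc(C(=O)/C=C/c2cc(-c3cc(OC)c(OC)c(OC)c3)n[nH]2)cc1OC` is not yet measured. It differs from compound 2 by 3,4-dimethoxyphenyl in place of 3,4-dichlorophenyl on a carbonyl carbon. Among the measured compounds shown here, the only measured step that bears on this position is the one from compound 1 to compound 2, and it ran toward a higher number when the 4-aminophenyl gave way to the 3,4-dichlorophenyl. For the measured compounds named here, since the 3,4-dimethoxyphenyl brings two hydrogen-bond acceptors where the 3,4-dichlorophenyl had none, a modest move back toward a lower number in this assay is expected for compound 3, about a 2.2-fold lower number from compound 2 to compound 3 (0.33 log units; beyond the scatter), though the data give no direct precedent. Compound 3 is therefore estimated at 2000 nM, within 700 nM to 6000 nM.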

Compound 3, concentration for 50% growth inhibition: 1270 nM
Estimate against measurement, compound 3: 1.6-fold (0.20 log units) above; the measured number falls inside the stated range.
By their numbers in this assay, from the lowest: compounds 3 and 1 (each within the scatter of the next); then compound 2.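

In this assay, the 3,4-dimethoxyphenyl in place of the 3,4-dichlorophenyl on the carbonyl carbon gives a 3.4-fold lower number from compound 2 to compound 3 (0.53 log units; beyond the scatter), so the higher number seen with the 3,4-dichlorophenyl is not shared by every other aryl group tried at this position. The step of a 1.0-fold lower number from compound 1 to compound 3 (0.01 log units; within the scatter) puts the 3,4-dimethoxyphenyl and the 4-aminophenyl level with each other, which leaves the 3,4-dichlorophenyl as the only one of the three that stands apart. Nothing measured here explains this difference.

The compounds shown leave open whether a single methoxy group, a hydroxyl group or a carboxylic acid on this aryl ring would give a number like those of compound 1 and compound 3. They also leave open whether one chlorine alone would give a number like that of compound 2.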